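Adding a Third Methoxy to Compound 2

The source may hold more compounds than are shown below. What is called first, only, known or untested is meant among the compounds shown, and "the series" means these compounds.

Compound 2 `COc1ccc(/C=N/NC(=O)c2cccnc2Nc2cccc(C(F)(F)F)c2)cc1OC` stands highest of the two numbers in a functional assay on the whole organism (strain Wistar) for inhibition, with Rattus norvegicus as the target, read by paw edema, with a stated time of 1 h, at a dose of 10 mg/kg by the intraperitoneal route (a higher number here means more inhibition at the dose given (going by the name of the read-out), a lower number less inhibition), giving 70%; compound 1 `O=C(N/N=C/c1ccc(O)c(O)c1)c1cccnc1Nc1cccc(C(F)(F)F)c1` gives 50.8%. Within the data shown here, the one measured step, a number 19.2 percentage points higher from compound 1 to compound 2 (beyond the scatter), concerned 3,4-dimethoxyphenyl in place of 3,4-dihydroxyphenyl on a carbon with a double bond to nitrogen. Compound 3 `COc1cc(/C=N/NC(=O)c2cccnc2Nc2cccc(C(F)(F)F)c2)cc(OC)c1OC` differs from compound 2 by methoxy in place of hydrogen on an aromatic carbon, the methoxy entering ortho to a methoxy group and meta to a methoxy group. That single step bears on this change only loosely, since it swapped two groups rather than adding one. The expected step is a number 2 percentage points higher from compound 2 to compound 3 (within the scatter), not beyond the scatter. Compound 3 is therefore expected to give 72%, between 55% and 85%.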

Compound 3, a percentage reported as inhibition, in the whole organism at one dose (the size of the read-out at that dose, not a potency): 54.4%
Estimate against measurement, compound 3: 17.6 percentage points above; measured number below the stated range.
By their numbers in this assay, from the lowest: compounds 1 and 3 (each within the scatter of the next); then compound 2.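

In this assay, adding the methoxy gave a number 15.6 percentage points lower from compound 2 to compound 3 (beyond the scatter), so a further group at this aromatic carbon lowered the number rather than raising it. The earlier step exchanged one pair of groups for another, so it could not show that this position, ortho to a methoxy group and meta to a methoxy group, responds to substitution at all. No measurement at hand accounts for the drop.

On these data alone, whether fluorine, a hydroxyl or an ethoxy at this carbon would do the same remains open. So does whether an amine there would keep the number of compound 2.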